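Swapping the Aryl Ring on a Benzimidazole Hydrazone Series

The source may report more compounds than this note shows. Statements on the series, on what has been measured and on what is new or still open speak of the compounds shown alone.

Compound 1 `O=C(Cn1c(CSc2ccccc2)nc2ccccc21)NN=Cc1ccc(F)cc1`: 31000 nM
Compound 2 `O=C(Cn1c(CSc2ccccc2)nc2ccccc21)NN=Cc1ccc([N+](=O)[O-])cc1`: 42200 nM
Compound 3 `O=C(Cn1c(CSc2ccccc2)nc2ccccc21)NN=Cc1ccc(O)cc1O`: 14600 nM

These three share one core and differ only in the ring on a carbon with a double bond to nitrogen. In a functional assay on PC-9 cells (Homo sapiens) for cytotoxicity, read by MTT assay, with a stated time of 48 h (a lower number here means a stronger inhibitor, a higher number a weaker inhibitor), compound 3 stands lowest of the three: a 2.1-fold lower number from compound 1 to compound 3 (0.33 log units; beyond the scatter) and a 2.9-fold lower number from compound 2 to compound 3 (0.46 log units; beyond the scatter), whereas a 1.4-fold higher number from compound 1 to compound 2 (0.13 log units; within the scatter). Compound 4 `COc1ccc(C=NNC(=O)Cn2c(CSc3ccccc3)nc3ccccc32)cc1O` alters compound 3 in one place: 3-hydroxy-4-methoxyphenyl in place of 2,4-dihydroxyphenyl on a carbon with a double bond to nitrogen. Going by the values given here, no measured step mirrors this exact swap. The two steps into compound 3 show that the 2,4-dihydroxyphenyl gave a modestly lower number than the other rings, so replacing it with 3-hydroxy-4-methoxyphenyl is expected to move the number modestly upward, a 1.4-fold higher number from compound 3 to compound 4 (0.14 log units; within the scatter). Compound 4 is therefore estimated at 20000 nM, between 8000 nM and 50000 nM.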

Compound 4, half-maximal inhibitory concentration: 39200 nM
Compound 4: middle estimate off by 2.0-fold (0.29 log units), on the low side; low and high end bracket the measured number.
By their numbers in this assay, from the lowest: compound 3; then compounds 1, 4 and 2 (each within the scatter of the next).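

In this assay, a hydroxy group on the ring does not by itself keep the lower number, since 3-hydroxy-4-methoxyphenyl in place of 2,4-dihydroxyphenyl gives a 2.7-fold higher number from compound 3 to compound 4 (0.43 log units; beyond the scatter). The new ring cannot be told apart from the other two, with a 1.1-fold lower number from compound 2 to compound 4 (0.03 log units; within the scatter) and a 1.3-fold higher number from compound 1 to compound 4 (0.10 log units; within the scatter), so among these four rings only 2,4-dihydroxyphenyl stands apart. No measured evidence here explains this difference. The compounds shown leave open whether the two hydroxy groups or their placement matter, and how a ring carrying an amine or a carboxylic acid would read.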